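The compounds below may be only part of what the source reports. "The series", "measured", "known", "first", "only" and "open" are said of these compounds alone.

In a functional assay on A549 cells (Homo sapiens) for inhibition, read by sulforhodamine B assay, with a stated time of 48 h (a lower number here means a stronger inhibitor of growth, a higher number a weaker inhibitor of growth), compound 3 `COC(=O)[C@@]1(C)CC[C@@H]2C3=C1CC[C@@H](C)[C@]3(C)Cc1c2[nH]c2c(C)cccc12` gives 16000 nM, second highest of the three numbers in hand. Compound 1 `COC(=O)[C@@]1(C)CCC=C2[C@@H]1CC[C@@H](C)[C@]2(C)Cc1c(C)[nH]c2c(C)cccc12` gives 14000 nM and compound 2 `COC(=O)[C@@]1(C)CCC=C2[C@@H]1CC[C@@H](C)[C@]2(C)Cc1c(C)[nH]c2c(Br)cccc12` gives 27000 nM in this assay; both sit within the scatter of compound 3.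

Compound 4 `COC(=O)[C@@]1(C)CC[C@@H]2C3=C1CC[C@@H](C)[C@]3(C)Cc1c2[nH]c2c(Cl)cccc12` differs from compound 3 by chloro in place of methyl on an aromatic carbon. Within the data shown here, the one measured step that bears on a halogen entering at this aromatic carbon is a 1.9-fold higher number from compound 1 to compound 2 (0.29 log units; within the scatter), bromo for methyl on the core of compound 1. On that basis the step is expected to stay small, with at most a slightly higher number, estimated as a 1.4-fold higher number from compound 3 to compound 4 (0.14 log units; within the scatter).

Compound 4 is therefore expected to give about 22000 nM in this assay, with a range of 9000 nM to 55000 nM.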

Compound 4, concentration for 50% growth inhibition: 21000 nM
Compound 4: the middle estimate sits 1.0-fold (0.02 log units) above what was measured; low and high end bracket the measured number.
By their numbers in this assay, from the lowest: compounds 1, 3, 4 and 2 (each within the scatter of the next).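

In this assay, chloro in place of methyl on this aromatic carbon gives a 1.3-fold higher number from compound 3 to compound 4 (0.12 log units; within the scatter), so the small halogen step seen earlier as a 1.9-fold higher number from compound 1 to compound 2 (0.29 log units; within the scatter), with bromo on the core of compound 1, also holds for chloro on the core of compound 3. On both cores, replacing methyl with a halogen at this position stays within the scatter. No measured evidence on the reason for this step is available.

Open, from the compounds shown here alone, is whether an amine, a carboxylic acid or a longer chain on this aromatic carbon would move the number beyond the scatter. Whether this position can influence growth inhibition at all also remains unsettled.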